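Moving the bromine on a hydroxybenzamide: an expected cytotoxicity

This account rests on a few compounds, and the source may have more. Where it says the series, first, only, none or still open, it means among the compounds named here.

Measured so far:
compound 1 `O=C(Nc1ccc(Sc2nc3ccccc3s2)cc1)c1cc(Br)ccc1O` — 42000 nM
compound 2 `COc1c(Br)cccc1C(=O)Nc1cccc(Cl)c1` — a limit, > 100000 nM

Two compounds were tested in an ADME assay on HEK293 cells (Homo sapiens) for cytotoxicity, read by reporter gene assay and resazurin assay, with a stated time of 48 h; on this read-out lower numbers stand for higher toxicity in this test and higher numbers for lower toxicity in this test. For the measured compounds named here, compound 1 gives 42000 nM, and this is the only actual number in the set. Compound 2 returns only a limit of the assay, > 100000 nM. Compound 1 therefore stands alone as a measured concentration, while the other entry is the limit of > 100000 nM in this assay, at which 1 of the 2 values shown sits.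

The unmeasured compound 3 `O=C(Nc1ccc(Sc2nc3ccccc3s2)cc1)c1cccc(Br)c1O` keeps the whole of compound 1 apart from one group, the two structures having the same atoms joined differently: 3-bromo-2-hydroxyphenyl in place of 5-bromo-2-hydroxyphenyl on a carbonyl carbon. Going by the values given here, no pair of measured compounds differing in one place is available, so the size of this kind of change cannot be read from a neighbouring step. With nothing to anchor a shift, the author expects the step in this assay to be small, no change at the digits printed from compound 1 to compound 3 (within the scatter), in no particular direction and not beyond the usual scatter of repeated measurements. Compound 3 is accordingly estimated at 42000 nM, with a range from 18000 nM to 100000 nM.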

Compound 3, half-maximal cytotoxic concentration: 71000 nM
Estimate against measurement, compound 3: 1.7-fold (0.23 log units) below; the measured number falls inside the stated range.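

In this assay, for the compounds shown here, the exchange of 5-bromo-2-hydroxyphenyl for 3-bromo-2-hydroxyphenyl on the carbonyl carbon gives a 1.7-fold higher number from compound 1 to compound 3 (0.23 log units; within the scatter) and is the first step in the set that can be read at all, since compound 2 differs from compound 1 in more than one place. It shows that, with the shared core kept and the same atoms joined differently, the two bromo-hydroxyphenyl groups cannot be told apart by this read-out, at least for this pair. Nothing measured here bears on why the pair behaves in this way.

Compound 2 remains a limit of the assay, > 100000 nM, and offers no number to compare with. Still open, from the compounds shown here alone, is whether a carboxylic acid or an amine in place of the bromine on the hydroxyphenyl group would move the value beyond the scatter, and whether the same exchange would give a step of this size on a core other than that of compound 1.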